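Phenoxypropoxy series: removing the ring halogen

A few compounds are considered here, and "the series" means these few. Any claim that something is new, unique, unknown or untested is made for them only; others in the source may bear on it.

Measured so far:
- compound 1 `NC1=NC2(CCOCC2)N(OCCCOc2cccc(Cl)c2)C(N)=N1` — 150 nM
- compound 2 `NC1=NC2(CCOCC2)N(OCCCOc2ccccc2Br)C(N)=N1` — 160 nM
- compound 3 `NC1=NC2(CCOCC2)N(OCCCOc2ccc(Br)cc2)C(N)=N1` — 280 nM

In a functional assay on A549 cells (Homo sapiens) for antiproliferative activity, read by MTT assay, with a stated time of 72 h (a lower number here means a stronger inhibitor, a higher number a weaker inhibitor), compound 1 gives the lowest of the three numbers, but its steps to the other two are both within the scatter: a 1.1-fold higher number from compound 1 to compound 2 (0.03 log units; within the scatter) and a 1.9-fold higher number from compound 1 to compound 3 (0.27 log units; within the scatter). The remaining pair behaves the same way, a 1.8-fold higher number from compound 2 to compound 3 (0.24 log units; within the scatter). Across the three compounds, moving the halogen around the phenoxy ring, or exchanging chloro for bromo, leaves the read-out essentially where it was.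

Compound 4 `NC1=NC2(CCOCC2)N(OCCCOc2ccccc2)C(N)=N1` differs from compound 1 in one place: hydrogen in place of chloro on an aromatic carbon. Among the measured compounds shown here, none of the measured steps removes a halogen outright, so no step bears directly on this change; all three steps only move or swap it, and each was within the scatter. The nearest evidence is therefore indirect and suggests the phenoxy halogen is not a strong lever in this assay. A small step toward a higher number is considered plausible, but nothing in the measured set supports a step beyond the scatter.

Compound 4 is expected to give about 260 nM (range 110 nM to 650 nM), which corresponds to an expected step of a 1.7-fold higher number from compound 1 to compound 4 (0.24 log units; within the scatter).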

Compound 4, half-maximal inhibitory concentration: 1080 nM
For compound 4 the middle estimate is 4.2-fold (0.62 log units) below the measured one; measured number outside the range, above it.
By their numbers in this assay, from the lowest: compounds 1, 2 and 3 (each within the scatter of the next); then compound 4.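

Hydrogen in place of the ring halogen gives a 7.2-fold higher number from compound 1 to compound 4 (0.86 log units; beyond the scatter) and a 6.8-fold higher number from compound 2 to compound 4 (0.83 log units; beyond the scatter) and also a 3.9-fold higher number from compound 3 to compound 4 (0.59 log units; beyond the scatter) in this assay for this change. The earlier steps shown here only moved or swapped the halogen, so they could not show what these three do: the presence of a halogen on the phenoxy ring matters here far more than its identity or position, and compound 4 is the weakest of the four, with none of the 3-chlorophenyl, 2-bromophenyl or 4-bromophenyl compounds going against this. Nothing available accounts for the size of this loss.

Still open, going by these compounds, is whether this gain belongs to chloro and bromo alone or extends to fluoro, methyl, methoxy or trifluoromethyl on the same ring. Also open, on these data alone, is whether the halogen keeps its weight with a shorter or longer chain in place of the propoxy link, or with two chloro groups on the ring.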